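A few compounds are considered here, and "the series" means these few. Any claim that something is new, unique, unknown or untested is made for them only; others in the source may bear on it.

Three compounds share one core: compound 1 `CN1CCN(Cc2csc(N)c2C(=O)c2ccc(Cl)cc2)CC1`, compound 2 `Nc1scc(CN2CCN(c3ccccc3)CC2)c1C(=O)c1ccc(Cl)cc1` and compound 3 `N#Cc1ccc(N2CCN(Cc3csc(N)c3C(=O)c3ccc(Cl)cc3)CC2)cc1`. In an assay on CHO cells for displacement of a labelled ligand from adenosine receptor A1 (Homo sapiens) (on this read-out higher numbers stand for weaker binding and lower numbers for tighter binding), compound 1 gives 1.2 nM, compound 2 gives 1 nM and compound 3 gives 1.1 nM; all three numbers lie within the scatter of one another, so compound 3 cannot be set apart from either of the others. Compound 4 `Nc1scc(CN2CCN(c3ccccn3)CC2)c1C(=O)c1ccc(Cl)cc1` differs from compound 3 by pyridin-2-yl in place of 4-cyanophenyl on an amine nitrogen in a ring. The steps that change the group at this same position, a 1.2-fold lower number from compound 1 to compound 2 (0.08 log units; within the scatter) and a 1.1-fold lower number from compound 1 to compound 3 (0.04 log units; within the scatter), together with a 1.1-fold higher number from compound 2 to compound 3 (0.04 log units; within the scatter), were all within the scatter. No step beyond the scatter is therefore expected in this assay for compound 4 in either direction. Compound 4 is expected to give 1.1 nM, in the range 0.5 nM to 2.5 nM. The step expected is no change at the digits printed from compound 3 to compound 4 (within the scatter).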

Compound 4, dissociation constant: 1.2 nM
Beside the measured number, compound 4's estimate is 1.1-fold (0.04 log units) below it, and the stated range covers the measured number.
By their numbers in this assay, from the lowest: compounds 2, 3, 1 and 4 (each within the scatter of the next).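

In this assay the position on the amine nitrogen in a ring also accepts pyridin-2-yl, a six-membered aromatic ring with 1 hetero atom, with every step within the scatter: against 4-cyanophenyl (a 1.1-fold higher number from compound 3 to compound 4 (0.04 log units; within the scatter)), against phenyl (a 1.2-fold higher number from compound 2 to compound 4 (0.08 log units; within the scatter)) and against methyl (no change at the digits printed from compound 1 to compound 4 (within the scatter)). The four groups at this position therefore cannot be told apart in this assay, whether the group is an aromatic ring of carbon only, an aromatic ring with a hetero atom or methyl. Nothing available explains this result. From the compounds shown here alone, it remains open whether a carboxylic acid or a longer chain on this nitrogen would give a step beyond the scatter.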